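Heteroaryl swaps and an alkyl extension on the shared core

This account rests on a few compounds, and the source may have more. Where it says the series, first, only, none or still open, it means among the compounds named here.

Measured so far in an assay on brain for displacement of a labelled ligand from D(3) dopamine receptor (Rattus norvegicus); a lower number here means a stronger inhibitor, a higher number a weaker inhibitor:
Compound 1, `CCCN(CC[C@H]1CC[C@H](NC(=O)c2ccc(-n3cccn3)cc2)CC1)[C@H]1CCc2nc(N)sc2C1`: compound 1 gives 3 nM.
Compound 2, `CCCN(CC[C@H]1CC[C@H](NC(=O)c2ccc(-n3cncn3)cc2)CC1)[C@H]1CCc2nc(N)sc2C1`: compound 2 gives 2.4 nM.
Compound 3, `CCCN(CC[C@H]1CC[C@H](NC(=O)c2ccc(-c3noc(CC)n3)cc2)CC1)[C@H]1CCc2nc(N)sc2C1`: compound 3 gives 2.1 nM.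

Compound 3 holds the lowest of the three numbers, but its lead is small: a 1.1-fold lower number from compound 2 to compound 3 (0.06 log units; within the scatter) and a 1.4-fold lower number from compound 1 to compound 3 (0.15 log units; within the scatter) both sit within the scatter, as does a 1.3-fold lower number from compound 1 to compound 2 (0.10 log units; within the scatter). All three measured steps exchange the whole five-membered ring on the aromatic carbon and none moved the number beyond the scatter.

Compound 4, `CCCN(CC[C@H]1CC[C@H](NC(=O)c2ccc(-c3noc(C(C)C)n3)cc2)CC1)[C@H]1CCc2nc(N)sc2C1`, differs from compound 3 by methyl in place of hydrogen on a saturated chain carbon bound to an aromatic carbon and a saturated chain carbon. No measured step touches this chain, so the three ring exchanges bear on it only indirectly, and they give no reason to expect a shift beyond the scatter. The expected step is a 1.1-fold lower number from compound 3 to compound 4 (0.02 log units; within the scatter). Compound 4 is therefore estimated at 2 nM, in the range 0.9 nM to 4.5 nM.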

Compound 4, inhibition constant: 2 nM
Estimate against measurement, compound 4: no gap at the digits printed; the range from low to high includes it.
By their numbers in this assay, from the lowest: compounds 4, 3, 2 and 1 (each within the scatter of the next).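

Among the compounds shown here, on the saturated chain carbon bound to an aromatic carbon, the change from ethyl to isopropyl gives in this assay a 1.1-fold lower number from compound 3 to compound 4 (0.02 log units; within the scatter) and so adds the first reading at this position, with the added methyl staying within the scatter. With isopropyl in place, the exchanges of the whole five-membered ring also stay within the scatter, at a 1.2-fold lower number from compound 2 to compound 4 (0.08 log units; within the scatter) and at a 1.5-fold lower number from compound 1 to compound 4 (0.18 log units; within the scatter). No evidence on hand accounts for these results.

Open, going by these compounds, is whether a longer chain such as n-butyl, or an amine or a carboxylic acid, in place of the isopropyl would stay within the scatter.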